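Aryl group on the ring nitrogen: outlook for compound 4

This account rests on a few compounds, and the source may have more. Where it says the series, first, only, none or still open, it means among the compounds named here.

Measured compounds in a functional assay on MCF7 cells (Homo sapiens) for antiproliferative activity, read by MTT assay, with a stated time of 48 h; a higher number here means a weaker inhibitor, a lower number a stronger inhibitor:
compound 1 `Cc1cccc(-n2nncc2CN2C(=O)C3(C(C#N)=C(N)Oc4c3c3nc5ccccc5nc3c3ccccc43)c3ccccc32)c1` gives > 50000 nM, which is a limit of the assay.
compound 2 `N#CC1=C(N)Oc2c(c3nc4ccccc4nc3c3ccccc23)C12C(=O)N(Cc1cnnn1-c1cccc(Br)c1)c1ccccc12` gives > 50000 nM, also a limit.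
compound 3 `N#CC1=C(N)Oc2c(c3nc4ccccc4nc3c3ccccc23)C12C(=O)N(Cc1cnnn1-c1ccc([N+](=O)[O-])cc1)c1ccccc12` gives > 50000 nM, again a limit.

Compound 3 thus stands at the limit with no number of its own, and the two other values shown do the same, which together make up (the limit of > 50000 nM in this assay, at which 3 of the 3 values shown sit). The steps a step that the two limits leave unreadable from compound 1 to compound 2, a step that the two limits leave unreadable from compound 1 to compound 3 and a step that the two limits leave unreadable from compound 2 to compound 3 are all unreadable, since both ends of each sit at that limit; they give neither a size nor a direction.

Compound 4 `Cc1ccc(C)c(-n2nncc2CN2C(=O)C3(C(C#N)=C(N)Oc4c3c3nc5ccccc5nc3c3ccccc43)c3ccccc32)c1` differs from compound 3 by 2,5-dimethylphenyl in place of 4-nitrophenyl on an aromatic nitrogen. Compound 1 already carries a 3-methylphenyl on an aromatic nitrogen of the same ring and sits at the limit, and compound 4 carries a 2,5-dimethylphenyl there instead. Going by the values given here, no measured step on this nitrogen has yielded a readable number, so there is no basis for expecting compound 4 to leave the limit. The expected step that the limit leaves unreadable from compound 3 to compound 4 is therefore one that cannot be read as a change. Compound 4 is estimated at 60000 nM in this assay, within 20000 nM to 200000 nM, and most likely to be reported as a limit once more.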

Compound 4, half-maximal inhibitory concentration: > 50000 nM
Compound 4: a limit, no number (the forecaster's own chance of this, stated with the estimate: 85%); the middle value lies beyond the limit too.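

In this assay compound 4 gives > 50000 nM, which is a limit and not a number. Its steps from compound 1, compound 2 and compound 3 cannot be read, in size or direction: the limit of > 50000 nM in this assay, at which 4 of the 4 values shown sit.

The compounds shown leave open whether any aryl group on this ring nitrogen, or any change elsewhere on the shared core, gives a readable value in this assay.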